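Cyclopropane Aryl Swap in a GPR88 Agonist Series

The source may hold more compounds than are shown below. What is called first, only, known or untested is meant among the compounds shown, and "the series" means these compounds.

Measured compounds:
Compound 1: `O=C([C@@H]1C[C@H]1c1ccccc1)N(CC1CCCNC1)c1ccc(-c2ccccc2)cc1`, 10 nM in a functional assay for agonist activity at G protein-coupled receptor 88 (Homo sapiens), read by HTRF and cAMP accumulation; on this read-out higher numbers stand for an effect only at larger amounts of compound and lower numbers for an effect already at smaller amounts.
Compound 2: `CC[C@H](C)[C@H](N)CN(C(=O)[C@@H]1C[C@H]1c1cccc(Cl)c1)c1ccc(-c2ccccc2)cc1`, 2200 nM in this assay.

Compound 2 stands at the highest of the two numbers recorded in this assay; its nearest neighbour is compound 1, whose number is lower by a gap well beyond the scatter. Among the measured compounds shown here, the two structures differ in several places at once, so no single-point step between them is recorded, and only the two values themselves can be compared.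

Compound 3, `CC[C@H](C)[C@H](N)CN(C(=O)[C@@H]1C[C@H]1c1ccoc1)c1ccc(-c2ccccc2)cc1`, is not yet measured. Its difference from compound 2 is furan-3-yl in place of 3-chlorophenyl on a saturated ring carbon. For the measured compounds named here, no pair of measured compounds carries this change, so the direction and size of the step rest on no precedent.

With nothing to anchor it, the step is expected to stay close to flat, with a modest lean toward a higher number: a 1.6-fold higher number from compound 2 to compound 3 (0.20 log units; within the scatter) is the expected change in this assay. Compound 3 is therefore estimated at 3500 nM in this assay, within a range of 800 nM to 15000 nM.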

Compound 3, half-maximal effective concentration: 580 nM
Compound 3: the middle estimate sits 6.0-fold (0.78 log units) above what was measured; measured number below the stated range.
By their numbers in this assay, from the lowest: compound 1; then compound 3; then compound 2.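

This position, on a saturated ring carbon of the three-membered ring, responds to the group it carries: in this assay, furan-3-yl in place of 3-chlorophenyl gives a 3.8-fold lower number from compound 2 to compound 3 (0.58 log units; beyond the scatter). The 3-chlorophenyl group is therefore not needed to keep activity in this pair, and the five-membered aromatic ring, with 5 heavy atoms against 7 and 1 hydrogen-bond acceptor against 0, gives the lower number, with compound 3 at 580 nM. No measurement available here accounts for this step.

Among the compounds shown here, with only this one pair, the lower number cannot be assigned to the loss of chlorine, the change in ring size or the ring oxygen; thiophen-3-yl, furan-2-yl and pyridin-3-yl at the same position would begin to separate these differences. As far as these compounds go, compound 1 differs from compound 3 in more than one place, so it remains open whether the same swap would lower the number by a similar amount in the setting of compound 1.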